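Benzylselanyl for Methylsulfanyl on Two Related Cores

A few compounds are considered here, and "the series" means these few. Any claim that something is new, unique, unknown or untested is made for them only; others in the source may bear on it.

Compound 1, `CS/C(=N\C(=O)c1ccno1)NC(=O)c1ccno1`, was tested in a functional assay on K562 cells (Homo sapiens) for cytotoxicity, read by MTT assay, with a stated time of 72 h; a lower number here means a stronger inhibitor of growth, a higher number a weaker inhibitor of growth. In this assay compound 1 gives only a limit, > 100000 nM. Compound 3, `O=C(/N=C(/NC(=O)c1ccno1)[Se]Cc1ccccc1)c1ccno1`, carries the change (a group of 8 heavy atoms (7 carbon, 1 selenium; one six-membered aromatic ring of carbon only) in place of a group of 2 heavy atoms (1 carbon, 1 sulfur; no ring), on a carbon with a double bond to nitrogen), and in this assay compound 3 gives 20000 nM. The step from the first to the second is an at least 5.0-fold lower number from compound 1 to compound 3 (0.69 log units; beyond the scatter); its size is known only as a lower bound because the value of compound 1 is the limit of > 100000 nM in this assay, at which 1 of the 3 values shown sits.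

Compound 2, `CS/C(=N\C(=O)c1cc2ccccc2s1)NC(=O)c1cc2ccccc2s1`, has a different core; the difference between the two cores is not broken down here. In this assay compound 2 gives 34700 nM, which lies within the usual scatter of the value of compound 3.

Compound 4, `O=C(/N=C(/NC(=O)c1cc2ccccc2s1)[Se]Cc1ccccc1)c1cc2ccccc2s1`, has not yet been measured. It differs from compound 2 by a group of 8 heavy atoms (7 carbon, 1 selenium; one six-membered aromatic ring of carbon only) in place of a group of 2 heavy atoms (1 carbon, 1 sulfur; no ring), on a carbon with a double bond to nitrogen, the same kind of change as that from compound 1 to compound 3, made at a place described in the same words. The expectation rests on that single measured pair: since the step of an at least 5.0-fold lower number from compound 1 to compound 3 (0.69 log units; beyond the scatter) lowered the number, the step from compound 2 to compound 4 is estimated as a 5.0-fold lower number from compound 2 to compound 4 (0.70 log units; beyond the scatter). Only one prior instance of this change exists among these compounds, and it is on a different core, so the expectation is loose. Compound 4 is therefore estimated to give about 7000 nM in this assay, most likely between 2500 nM and 20000 nM.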

Compound 4, concentration for 50% growth inhibition: 14900 nM
Compound 4: the middle estimate sits 2.1-fold (0.33 log units) below what was measured, and the stated range covers the measured number.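

In this assay, benzylselanyl in place of methylsulfanyl on the second core gives a 2.3-fold lower number from compound 2 to compound 4 (0.37 log units; beyond the scatter), a lower number, as on the first core, and the two steps can be set side by side: the same change on two cores in this assay, an at least 5.0-fold lower number (0.69 log units; beyond the scatter) from compound 1 to compound 3 and a 2.3-fold lower number (0.37 log units; beyond the scatter) from compound 2 to compound 4; the limit leaves it open whether they differ The direction of the change therefore carries from one core to the other in both pairs shown, and each step lies beyond the scatter, though two pairs on two cores are too few to support a rule for the wider series. How far the size of the step carries over is not shown, for compound 1 supplies a limit and not a number: the limit of > 100000 nM in this assay, at which 1 of the 4 values shown sits.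

The change swaps the selenium for the sulfur and the benzyl for the methyl at the same time, so the compounds shown leave open which of the two accounts for the lower number, a question that methylselanyl and benzylsulfanyl on these cores would address. They also leave open how a longer chain on the selenium, such as phenethylselanyl, or an amine on the carbon with a double bond to nitrogen would read in this assay, and whether the same step would appear on a third core.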